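Acetyl on the Ring Nitrogen: Expected Inhibition for Compound 3

The compounds below may be only part of what the source reports. "The series", "measured", "known", "first", "only" and "open" are said of these compounds alone.

Compound 1 `COc1ccc(C2CC(c3ccc(NC(=O)c4cc(Cl)ccc4OC)cc3)=NN2c2ccccc2)cc1`: 82.3%
Compound 2 `COc1ccc(C2CC(c3ccc(NC(=O)c4cc(Cl)ccc4OC)cc3)=NN2)cc1`: 70.6%

In a functional assay on the whole organism (plasma, strain albino) for inhibition, with Rattus norvegicus as the target, with stated times of 1 h and 4 h, at a dose of 25 mg/kg by the oral route (on this read-out higher numbers stand for a stronger effect at the one dose given and lower numbers for a weaker effect), compound 1 gives 82.3% and compound 2 gives 70.6%. Compound 2 therefore stands lowest of the two numbers shown, and the one step measured, a number 11.7 percentage points lower from compound 1 to compound 2 (beyond the scatter), came from hydrogen in place of phenyl on an amine nitrogen in a ring.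

Compound 3 `COc1ccc(C2CC(c3ccc(NC(=O)c4cc(Cl)ccc4OC)cc3)=NN2C(C)=O)cc1` has not yet been measured. It differs from compound 2 by acetyl in place of hydrogen on an amine nitrogen in a ring. Among the compounds with values here, the same ring nitrogen is the place where the one measured step occurred, so that step is the only one that bears on the change. Read in reverse, it shows that putting a group on this nitrogen instead of hydrogen raised the number by a modest amount beyond the scatter. Acetyl is a smaller group than phenyl and the shared core is otherwise untouched, so a modest rise or no step beyond the scatter is expected, with the estimated step of a number 5.4 percentage points higher from compound 2 to compound 3 (within the scatter). Compound 3 is estimated at 76%, within a range from 64% to 88%.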

Compound 3, a percentage reported as inhibition, in the whole organism at one dose (the size of the read-out at that dose, not a potency): 79.4%
The estimate for compound 3 lay 3.4 percentage points below the measured number; the range from low to high includes it.
By their numbers in this assay, from the lowest: compounds 2, 3 and 1 (each within the scatter of the next, the first and the last beyond it).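

In this assay, putting acetyl in place of hydrogen on the amine nitrogen in the ring gives a number 8.8 percentage points higher from compound 2 to compound 3 (within the scatter), while putting acetyl in place of phenyl at the same atom gives a number 2.9 percentage points lower from compound 1 to compound 3 (within the scatter). Compound 1 and compound 2 are separated by more than the usual scatter, but compound 3 lies within the scatter of both, so this single result cannot place acetyl with either hydrogen or phenyl. It does show that, among these three compounds, a ring on this nitrogen is not needed for a number within the scatter of compound 1, since acetyl contains no ring, yet it does not establish a real gain over hydrogen. No measurement is available that explains how any of these groups affects the read-out.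

Still open, on these data alone, is what a methyl, a longer chain such as butyryl, or a benzoyl group on this nitrogen would give, and whether any of them would separate clearly from compound 2. The read-out also comes from one oral dose, so these numbers show only the size of the effect at that dose and say nothing about other doses.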